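Replacing methoxy with dimethylamino in a growth-inhibitor series

This account rests on a few compounds, and the source may have more. Where it says the series, first, only, none or still open, it means among the compounds named here.

For the measured compounds named here, in a functional assay on KB cells (Homo sapiens) for inhibition, read by sulforhodamine B assay (a lower number here means a stronger inhibitor of growth, a higher number a weaker inhibitor of growth), compound 1 (`Oc1cccc2[nH]c(-c3ccc(-c4ccc(-c5ccc(F)cc5)cc4)cc3)nc12`) gives 6920 nM and compound 2 (`COc1ccc(-c2ccc(-c3ccc(-c4nc5c(O)cccc5[nH]4)cc3)cc2)cc1`) gives 4900 nM, so compound 2 stands within the scatter of the only other measured compound. Compound 3 (`CN(C)c1ccc(-c2ccc(-c3ccc(-c4nc5c(O)cccc5[nH]4)cc3)cc2)cc1`) carries dimethylamino in place of methoxy on an aromatic carbon, para to a large group (dimethylamino in place of methoxy on an aromatic carbon). Going by the values given here, the one measured step at that carbon, a 1.4-fold lower number from compound 1 to compound 2 (0.15 log units; within the scatter), is small, so no change beyond the scatter is expected in this assay. The estimated step is a 1.1-fold lower number from compound 2 to compound 3 (0.04 log units; within the scatter). Compound 3 is expected at 4500 nM, within an estimated range of 2000 nM to 10000 nM.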

Compound 3, concentration for 50% growth inhibition: 4200 nM
Compound 3: middle estimate off by 1.1-fold (0.03 log units), on the high side, within the range that was stated.
By their numbers in this assay, from the lowest: compounds 3, 2 and 1 (each within the scatter of the next).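

In this assay, the new group at this aromatic carbon gives a 1.2-fold lower number from compound 2 to compound 3 (0.07 log units; within the scatter) when set against methoxy, and a 1.6-fold lower number from compound 1 to compound 3 (0.22 log units; within the scatter) when set against fluoro, so all three groups tried at this carbon now lie within the scatter of one another. An amine at this carbon thus reads no differently here from an ether or a halogen. Nothing available accounts for this closeness. As far as these compounds go, whether a carboxylic acid or a longer chain at this carbon would move the number beyond the scatter stays open, as does the effect of changes elsewhere on the shared core.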